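The compounds below may be only part of what the source reports. "The series", "measured", "known", "first", "only" and "open" are said of these compounds alone.

Measured in a functional assay on HEK293 cells for antagonist activity at melanin-concentrating hormone receptor 1 (Rattus norvegicus), read by FLIPR; on this read-out higher numbers stand for weaker inhibition and lower numbers for stronger inhibition:
- compound 1 `CC(C)C(=O)Nc1cccc(C2CCN(Cc3ccc(Oc4ccccc4)cc3)CC2)c1` gives 320 nM
- compound 2 `COc1ccc(Oc2ccc(CN3CCC(c4cccc(NC(=O)C(C)C)c4)CC3)cc2)cc1` gives 720 nM

Of these two numbers, compound 2 has the higher one, and the step of a 2.3-fold higher number from compound 1 to compound 2 (0.35 log units; beyond the scatter) lies beyond the scatter. Compound 3 `CC(C)C(=O)Nc1cccc(C2CCN(Cc3ccc(Oc4ccc(Cl)c(Cl)c4)cc3)CC2)c1` has not yet been tested. It differs from compound 2 by 3,4-dichlorophenyl in place of 4-methoxyphenyl on an oxygen on an aromatic ring. Among the measured compounds shown here, no measured step exchanges one aryl group for another; the only known step, hydrogen to methoxy, touches a different place and offers only a loose guide. The expected step of a 2.1-fold lower number from compound 2 to compound 3 (0.31 log units; beyond the scatter) is therefore stated with a wide range. Compound 3 is estimated at 350 nM in this assay, between 80 nM and 1500 nM.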

Compound 3, half-maximal inhibitory concentration: 710 nM
Estimate against measurement, compound 3: 2.0-fold (0.31 log units) below; low and high end bracket the measured number.
By their numbers in this assay, from the lowest: compound 1; then compounds 3 and 2 (each within the scatter of the next).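

In this assay, 3,4-dichlorophenyl and 4-methoxyphenyl on this oxygen cannot be told apart (a 1.0-fold lower number from compound 2 to compound 3 (0.01 log units; within the scatter)). Both substituted rings give a higher number, meaning weaker inhibition, than the plain phenyl of compound 1 (a 2.3-fold higher number from compound 1 to compound 2 (0.35 log units; beyond the scatter); a 2.2-fold higher number from compound 1 to compound 3 (0.35 log units; beyond the scatter)), so two quite different substituted rings show the same modest loss. Nothing available explains this result.

Still open, from the compounds shown here alone, is whether a single fluorine on this ring would also give a higher number than compound 1. So is whether an amine or a carboxylic acid there would do the same.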